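Changing the aryl group on the acyl urea of compound 3

This account rests on a few compounds, and the source may have more. Where it says the series, first, only, none or still open, it means among the compounds named here.

Measured so far:
compound 1, `CN(C(=O)NC(=O)c1ccc(F)c(F)c1)c1nc(C(F)(F)F)c(C(=O)N/N=C/c2ccc(C(F)(F)F)cc2)s1`, 3.85 ug/mL
compound 2, `CN(C(=O)NC(=O)c1ccc(Cl)cc1Cl)c1nc(C(F)(F)F)c(C(=O)N/N=C/c2cccc(C(F)(F)F)c2)s1`, 6.11 ug/mL
compound 3, `CN(C(=O)NC(=O)c1ccc(Cl)cc1Cl)c1nc(C(F)(F)F)c(C(=O)N/N=C/c2ccc(C(F)(F)F)cc2)s1`, 3.08 ug/mL

In a functional assay on BCG823 cells (Homo sapiens) for inhibition, read by MTT assay, with a stated time of 72 h (on this read-out lower numbers stand for stronger inhibition and higher numbers for weaker inhibition), compound 3 stands at the lowest of the three numbers, yet its steps to compound 1 and compound 2 both lie within the scatter, so the three compounds cannot be separated. Compound 4 `CN(C(=O)NC(=O)c1cccc(C(F)(F)F)c1)c1nc(C(F)(F)F)c(C(=O)N/N=C/c2ccc(C(F)(F)F)cc2)s1` differs from compound 3 by 3-(trifluoromethyl)phenyl in place of 2,4-dichlorophenyl on a carbonyl carbon. Going by the values given here, only one measured step touches the same carbonyl carbon, a 1.3-fold lower number from compound 1 to compound 3 (0.10 log units; within the scatter), and it stayed within the scatter; the other step, a 2.0-fold lower number from compound 2 to compound 3 (0.30 log units; within the scatter), concerns a different place and was also within the scatter. Aryl swaps in this series have therefore not moved the number noticeably, and the expected step is none beyond the scatter, a 1.2-fold higher number from compound 3 to compound 4 (0.07 log units; within the scatter). Compound 4 is estimated at 3.6 ug/mL, with a range from 1.6 ug/mL to 8 ug/mL.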

Compound 4, half-maximal inhibitory concentration: 4.22 ug/mL
Beside the measured number, compound 4's estimate is 1.2-fold (0.07 log units) below it; low and high end bracket the measured number.
By their numbers in this assay, from the lowest: compounds 3, 1, 4 and 2 (each within the scatter of the next).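

In this assay, a third aryl group on this carbonyl carbon leaves the number within the scatter: replacing 2,4-dichlorophenyl gives a 1.4-fold higher number from compound 3 to compound 4 (0.14 log units; within the scatter), and replacing 3,4-difluorophenyl gives a 1.1-fold higher number from compound 1 to compound 4 (0.04 log units; within the scatter). The three aryl groups therefore cannot be told apart here. No measurement shown here explains this lack of separation. The aryl groups shown carry only chlorine, fluorine or trifluoromethyl, so it remains open whether an aryl group bearing an amine or a carboxylic acid would stay within the scatter. The same question applies to a non-aromatic group such as cyclohexyl.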